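The compounds below may be only part of what the source reports. "The series", "measured", "known", "first", "only" and "open" are said of these compounds alone.

Measured in an in vitro ADME assay on microsomes from liver (Homo sapiens) for pharmacokinetics, read by LC-MS, with a stated time of 10 min, tested at 1 uM; on this read-out higher numbers stand for fast clearance and lower numbers for slow clearance:
- compound 1 `CN1C[C@H](C(=O)Nc2ccc(F)cc2)[C@@H](c2ccc(/C=C/C(=O)Nc3ccccc3N)cc2)C1`: 5 mL/min/kg
- compound 2 `CN1C[C@H](C(=O)Nc2ccc(C#N)cc2)[C@@H](c2ccc(/C=C/C(=O)Nc3ccccc3N)cc2)C1`: 1 mL/min/kg
- compound 3 `CN1C[C@H](C(=O)Nc2cccnc2)[C@@H](c2ccc(/C=C/C(=O)Nc3ccccc3N)cc2)C1`: 10 mL/min/kg

Compound 3 stands at the high end of this small set, although its nearest neighbour lies within the scatter: a 2.0-fold higher number from compound 1 to compound 3 (0.30 log units; within the scatter). The next change gives compound 4 `CN1C[C@H](C(=O)Nc2ccc(Cl)cn2)[C@@H](c2ccc(/C=C/C(=O)Nc3ccccc3N)cc2)C1`, with 5-chloropyridin-2-yl in place of pyridin-3-yl on an amide-type nitrogen. Exchanges at that nitrogen bear most directly, and they range from the step above to a 10-fold higher number from compound 2 to compound 3 (1.00 log units; beyond the scatter). Changing only the ring substituent gave a 5.0-fold lower number from compound 1 to compound 2 (0.70 log units; beyond the scatter). Going by the values given here, no measured compound carries the entering group, so the guidance is loose. The expected step is small and is estimated as a 1.7-fold lower number from compound 3 to compound 4 (0.22 log units; within the scatter). For compound 4 the estimated clearance is 6 mL/min/kg, with an expected range of 2 mL/min/kg to 15 mL/min/kg.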

Compound 4, clearance: 13 mL/min/kg
Compound 4: the middle estimate sits 2.2-fold (0.34 log units) below what was measured, and the stated range covers the measured number.
By their numbers in this assay, from the lowest: compound 2; then compounds 1, 3 and 4 (each within the scatter of the next, the first and the last beyond it).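

In this assay, 5-chloropyridin-2-yl on the amide-type nitrogen reads level with pyridin-3-yl (a 1.3-fold higher number from compound 3 to compound 4 (0.11 log units; within the scatter)). Both pyridine compounds stand clear of compound 2, with compound 4 the further off (a 13-fold higher number from compound 2 to compound 4 (1.11 log units; beyond the scatter)), and compound 4 also separates from compound 1 beyond the scatter (a 2.6-fold higher number from compound 1 to compound 4 (0.41 log units; beyond the scatter)), which compound 3 does not. No supporting measurement bears on these steps.

Open, going by these compounds, is whether 5-chloropyridin-3-yl would read with compound 3 or compound 4, which would separate the chlorine from the ring attachment. Also open, on these data alone, is how a non-aromatic group, such as a cyclohexyl ring, would read on this nitrogen.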